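The source may report more compounds than this note shows. Statements on the series, on what has been measured and on what is new or still open speak of the compounds shown alone.

In a functional assay on HeLa cells (Homo sapiens) for antiproliferative activity, read by MTT assay, with a stated time of 48 h (on this read-out lower numbers stand for stronger inhibition and higher numbers for weaker inhibition), compound 1 `N#Cc1nc2c(-c3nc4ccccc4[nH]3)c(N)n(CCCNc3ccccc3)c2nc1C#N` gives 26300 nM. From the compounds shown here alone, compound 2 `CN(C)CCCCn1c(N)c(C#N)c2nc(C#N)c(C#N)nc21` gives > 50000 nM, which is a limit of the assay and not a number, so its true position on this scale is unknown. Compound 3 `CN(C)CCCCn1c(N)c(-c2nc3cc(Cl)ccc3[nH]2)c2nc(C#N)c(C#N)nc21` keeps the 4-(dimethylamino)butyl group of compound 2 and carries 5-chloro-1H-benzimidazol-2-yl in place of cyano on an aromatic carbon. Going by the values given here, no measured pair isolates this change in this assay, so any expectation is indirect. Compound 1, which bears a closely similar group at that carbon but has a different chain, reached a measurable 26300 nM, and this points to stronger inhibition for compound 3. The expected change, an at least 3.3-fold lower number from compound 2 to compound 3 (0.52 log units; beyond the scatter), is modest and uncertain in size. For compound 3 the estimated value is 15000 nM, with an expected range of 4000 nM to 48000 nM.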

Compound 3, half-maximal inhibitory concentration: 3120 nM
Estimate against measurement, compound 3: 4.8-fold (0.68 log units) above, outside the stated range (below it).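

In this assay, going by these compounds alone, exchanging cyano for 5-chloro-1H-benzimidazol-2-yl on this aromatic carbon, with the 4-(dimethylamino)butyl group kept, gives an at least 16-fold lower number from compound 2 to compound 3 (1.20 log units; beyond the scatter) and is the first reading that isolates this position. It shows that this single change is enough to carry a compound from a limit to a measured value. The value of compound 2 is a limit and not a number, so the step gives only a minimum size: the limit of > 50000 nM in this assay, at which 1 of the 3 values shown sits.

From the compounds shown here alone, how much of the step belongs to the chlorine stays open, a question that the unsubstituted 1H-benzimidazol-2-yl group on the same chain would address. Going by these compounds, compound 1 differs from compound 3 in more than one place, so the role of the chain also stays open, and a morpholine in place of the dimethylamino group would test it.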